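Reshaping the Side Chain of Compound 3

A few compounds are considered here, and "the series" means these few. Any claim that something is new, unique, unknown or untested is made for them only; others in the source may bear on it.

In an ADME assay on S9 fraction from liver (Homo sapiens) for metabolic stability, with a stated time of 1 h (on this read-out higher numbers stand for a more stable compound and lower numbers for a less stable compound), compound 1 `N#Cc1cnc(NCc2ccccc2C(F)(F)F)cc1N[C@H]1CC[C@@H](O)CC1` gives 0%, compound 2 `N#Cc1cnc(NCc2cnccc2C(F)(F)F)cc1N[C@H]1CC[C@H](O)CC1` gives 30% and compound 3 `CO[C@H]1CC[C@@H](Nc2cc(NCc3cnccc3C(F)(F)F)ncc2C#N)CC1` gives 19%, which places compound 3 second of the three. Compound 4 `N#Cc1cnc(NCc2cnccc2C(F)(F)F)cc1NCCC1CCOCC1` has the same atoms joined differently: 2-(oxan-4-yl)ethyl in place of 4-methoxycyclohexyl on a nitrogen on an aromatic ring. In short, 2-(oxan-4-yl)ethyl takes the place of 4-methoxycyclohexyl on a nitrogen on an aromatic ring. Among the measured compounds shown here, only one measured step changes this group: a number 11 percentage points lower from compound 2 to compound 3 (beyond the scatter). For the measured compounds named here, that modest step offers a rough guide to size, but no measured compound carries the new group, so the direction remains open. The expected result is only a small step, a number 3 percentage points higher from compound 3 to compound 4 (within the scatter). Compound 4 is estimated at 22%, with an expected range of 6% to 45%.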

Compound 4, percent of the compound remaining: 23%
Compound 4: middle estimate off by 1 percentage points, on the low side; the measured number falls inside the stated range.
By their numbers in this assay, from the lowest: compound 1; then compounds 3, 4 and 2 (each within the scatter of the next, the first and the last beyond it).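

Swapping 4-methoxycyclohexyl for 2-(oxan-4-yl)ethyl on this nitrogen keeps the same atoms and loses the defined stereocentres, yet gives a number 4 percentage points higher from compound 3 to compound 4 (within the scatter) in this assay. Set against the 4-hydroxycyclohexyl group, the new group gives a number 7 percentage points lower from compound 2 to compound 4 (within the scatter), so this rearranged side chain cannot be told apart from either cyclohexyl compound. Nothing available explains why these side chains read so alike. Still open, on these data alone, is how this assay would respond to an amine or a carboxylic acid at the end of this side chain. A longer chain between the nitrogen and the oxane ring is equally untested by the compounds shown.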